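A few compounds are considered here, and "the series" means these few. Any claim that something is new, unique, unknown or untested is made for them only; others in the source may bear on it.

Working notes on the series.

Compound 1 `Cc1nc2nccc-2c(NC(C)C)[nH]1` gives 550000000 nM in a functional assay on the whole organism for inhibition, with Nicotiana tabacum as the target; a higher number here means a weaker inhibitor, a lower number a stronger inhibitor. Compound 2 `CCC(C)Nc1[nH]c(C)nc2nccc1-2` gives 174000000 nM; it stands second highest of the three numbers, with compound 1 nearest and compound 3 furthest. Compound 3 `Cc1nc(NCCCO)c2cc[nH]c2n1` differs from compound 2 both in its chain and in the arrangement of the shared core; in this assay compound 3 gives 17800000 nM, the lowest number of the three. For the measured compounds named here, the only single-place step in the set is a 3.2-fold lower number from compound 1 to compound 2 (0.50 log units; beyond the scatter), a modest change that goes with adding a methyl on the chain.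

Compound 4 `COCCNc1[nH]c(C)nc2nccc1-2` carries 2-methoxyethyl in place of sec-butyl on a nitrogen on an aromatic ring. Going by the values given here, no measured step covers this change directly; the step from compound 1 to compound 2 touches only branching of the chain, and compound 3 differs from compound 2 in two places. On that thin basis compound 4 is expected to remain in the range of compound 2, with a 1.1-fold higher number from compound 2 to compound 4 (0.06 log units; within the scatter) the expected step, and its estimated value is 200000000 nM, between 50000000 nM and 800000000 nM.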

Compound 4, half-maximal inhibitory concentration: 166000000 nM
Estimate against measurement, compound 4: 1.2-fold (0.08 log units) above, and the stated range covers the measured number.
By their numbers in this assay, from the lowest: compound 3; then compounds 4 and 2 (each within the scatter of the next); then compound 1.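

At this position, on a nitrogen on an aromatic ring, replacing sec-butyl with 2-methoxyethyl keeps the heavy-atom count at four, swaps one carbon for an oxygen and adds a hydrogen-bond acceptor, yet in this assay it gives a 1.0-fold lower number from compound 2 to compound 4 (0.02 log units; within the scatter), so the two compounds cannot be told apart. Starting from isopropyl, the same group gives a 3.3-fold lower number from compound 1 to compound 4 (0.52 log units; beyond the scatter), which stands close to a 3.2-fold lower number from compound 1 to compound 2 (0.50 log units; beyond the scatter), so two chains of different atom make-up lie at a similar distance from compound 1. Nothing available explains this result.

From the compounds shown here alone, it remains open whether a longer chain, an amine or a carboxylic acid in place of 2-methoxyethyl would move the number beyond the scatter on this core. Compound 3 differs from compound 2 in two places, so its lower number cannot be assigned to either the chain or the core arrangement.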